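This account rests on a few compounds, and the source may have more. Where it says the series, first, only, none or still open, it means among the compounds named here.

Measured compounds:
compound 1 `COc1cccc(-c2nc(SCC(=O)c3sc(-c4ccccc4)nc3C)[nH]c(=O)c2C#N)c1` — 90.2%
compound 2 `Cc1nc(-c2ccccc2)sc1C(=O)CSc1nc(-c2cccc(Cl)c2)c(C#N)c(=O)[nH]1` — 83.7%

In a functional assay on U-87MG ATCC cells for antiproliferative activity against U-87 MG (Homo sapiens), read by MTT assay, with a stated time of 48 h, tested at 10 uM (on this read-out higher numbers stand for a weaker effect at the one concentration tested and lower numbers for a stronger effect), compound 1 gives 90.2% and compound 2 gives 83.7%. Compound 2 carries the smaller figure of the two, but the gap a number 6.5 percentage points lower from compound 1 to compound 2 (within the scatter) is within the scatter, so the two compounds are not distinguished by this read-out.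

Compound 3 `Cc1nc(-c2ccccc2)sc1C(=O)CSc1nc(-c2ccc(Cl)cc2)c(C#N)c(=O)[nH]1` differs from compound 2 by 4-chlorophenyl in place of 3-chlorophenyl on an aromatic carbon. Among the compounds with values here, no measured step bears directly on this change: the only step, a number 6.5 percentage points lower from compound 1 to compound 2 (within the scatter), exchanged one group for another at the same place and was itself within the scatter. Nothing in the two numbers suggests that moving the chlorine on the phenyl ring would shift the read-out beyond the scatter, so no step beyond the scatter is expected.

Compound 3 is therefore expected near 85%, within 70% to 98%. The expected step of a number 1.3 percentage points higher from compound 2 to compound 3 (within the scatter) is estimated to lie within the scatter.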

Compound 3, a percentage reported as activity, at one concentration (the size of the read-out at that concentration, not a potency): 85.2%
Estimate against measurement, compound 3: 0.2 percentage points below, within the range that was stated.
By their numbers in this assay, from the lowest: compounds 2, 3 and 1 (each within the scatter of the next).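

In this assay, moving the chlorine from 3-chlorophenyl to 4-chlorophenyl, at the aromatic carbon ortho to a cyano group, gives a number 1.5 percentage points higher from compound 2 to compound 3 (within the scatter), so this read-out does not resolve where the chlorine sits on this phenyl ring. Exchanging 3-methoxyphenyl for 4-chlorophenyl gives a number 5 percentage points lower from compound 1 to compound 3 (within the scatter), so the three aryl groups at this position, which differ in substituent or its place on the ring, remain undistinguished at the one concentration tested. No measurement at hand accounts for this flat result.

The compounds shown leave open whether any group at this position can move the read-out beyond the scatter, for example an amine or a carboxylic acid on the phenyl ring. From the compounds shown here alone, whether changes elsewhere on the shared core matter more also remains open.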